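Hydroxy for Carbamoylmethyl: a Small Side-Chain Swap

The source may hold more compounds than are shown below. What is called first, only, known or untested is meant among the compounds shown, and "the series" means these compounds.

Measured compounds and their values in a functional assay on the whole organism (Tail, strain ICR) with Mus musculus as the target, in the tail flick test, with a stated time of 60 min, at a dose of 25 umol/kg by the oral route; a higher number here means a stronger effect of the compound at the dose given, a lower number a weaker effect:
Compound 1, `NC(=O)CC[C@H](NC(=O)CN(c1ncnc2c1ncn2C1CCCCO1)C1CC1)C(=O)OCc1ccccc1`, gives 39.4%.
Compound 2, `O=C(OCc1ccccc1)[C@@H]1CCCN1C(=O)CN(c1nc(Cl)nc2[nH]cnc12)C1CC1`, gives 34.4%.
Compound 3, `O=C(CN(c1nc(Cl)nc2[nH]cnc12)C1CC1)N[C@@H](CCC(=O)OCc1ccccc1)C(=O)OCc1ccccc1`, gives 53.7%.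

Among these three, compound 1 stands second highest. Its nearest neighbour is compound 2, whose value lies close enough to be within the usual scatter, so the two cannot be told apart. Compound 3 sits furthest away, with a value beyond the scatter above that of compound 1.

The next compound to be measured is compound 4, `O=C(CN(c1ncnc2c1ncn2C1CCCCO1)C1CC1)N[C@@H](CO)C(=O)OCc1ccccc1`. It keeps the core and the cyclopropyl group of compound 1 and changes only the side chain: hydroxy in place of carbamoylmethyl on a saturated chain carbon, two bonds along the chain from an amide-type nitrogen and a carbonyl carbon. Hydroxy in place of carbamoylmethyl is a reduction of a short chain ending in an amide to a single oxygen, on a saturated chain carbon two bonds along the chain from an amide-type nitrogen and a carbonyl carbon.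

Within the data shown here, no measured pair shows this exact change, so there is no comparison to lean on. With the side chain shortened and the amide removed, a modest change is expected for compound 4, and the step of a number 4.4 percentage points lower from compound 1 to compound 4 (within the scatter) is estimated to stay within the scatter, leaning slightly downward. Compound 4 is therefore expected to give 35% in this assay, within a range from 15% to 55%.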

Compound 4, a percentage reported as activity, at one dose (the size of the read-out at that dose, not a potency): 46.7%
For compound 4 the middle estimate is 11.7 percentage points below the measured one; measured number inside the range.
By their numbers in this assay, from the lowest: compounds 2, 1, 4 and 3 (each within the scatter of the next, the first and the last beyond it).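

Among these compounds, this pair offers the first comparison in this assay between two compounds that differ in one place: putting hydroxy in place of carbamoylmethyl, on a saturated chain carbon two bonds along the chain from an amide-type nitrogen and a carbonyl carbon, gives a number 7.3 percentage points higher from compound 1 to compound 4 (within the scatter) and so no readable change. The side chain at this position can therefore go from the four heavy atoms of carbamoylmethyl to the single oxygen of hydroxy, losing its amide end, while the two compounds remain impossible to tell apart in this whole-animal test. Nothing among the data shown offers an explanation for this outcome.

What the compounds shown leave open is whether any group at this place would move the read-out beyond the scatter, for instance a methyl, an amine, a carboxylic acid or a longer chain ending in an ester. Also open, on these data alone, is whether the same swap from carbamoylmethyl to hydroxy would give a similar outcome on the core of compound 3, which carries a different side chain.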